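The source may report more compounds than this note shows. Statements on the series, on what has been measured and on what is new or still open speak of the compounds shown alone.

Measured compounds in an assay on isolated protein for displacement of a labelled ligand from Oxytocin receptor (Homo sapiens); a lower number here means a stronger inhibitor, a higher number a weaker inhibitor:
- compound 1 `Cc1ccc([C@H](C(=O)N(C)C)N2C(=O)[C@@H](C3Cc4ccccc4C3)NC(=O)[C@H]2CC(C)C)cn1` gives 1.59 nM
- compound 2 `Cc1ccc([C@H](C(=O)N2CCCC2)N2C(=O)[C@@H](C3Cc4ccccc4C3)NC(=O)[C@H]2CC(C)C)cn1` gives 0.501 nM
- compound 3 `CCC(CC)[C@@H]1C(=O)N[C@H](C2Cc3ccccc3C2)C(=O)N1[C@@H](C(=O)N(C)C)c1ccc(C)nc1` gives 0.0501 nM

Compound 1 stands at the highest number of the three in this assay. Its nearest neighbour is compound 2, reached by a 3.2-fold lower number from compound 1 to compound 2 (0.50 log units; beyond the scatter) with pyrrolidin-1-yl in place of dimethylamino on the carbonyl carbon. Furthest is compound 3, reached by a 32-fold lower number from compound 1 to compound 3 (1.50 log units; beyond the scatter) with pentan-3-yl in place of isobutyl on a saturated ring carbon.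

Compound 4 `CC(C)C[C@@H]1C(=O)N[C@H](C2Cc3ccccc3C2)C(=O)N1[C@@H](C(=O)N(C)C)c1ccc(N(C)C)nc1` keeps the shared core of compound 1 and changes only the pyridine substituent: dimethylamino in place of methyl on an aromatic carbon. Neither measured step bears on this part of the molecule; the step to compound 2 alters the amide and the step to compound 3 alters the ring substituent, so there is no measured guide for the pyridyl group. With nothing to argue for a shift in either direction, the expectation for compound 4 is a step within the scatter, a 1.0-fold higher number from compound 1 to compound 4 (0.00 log units; within the scatter). Compound 4 is therefore estimated at 1.6 nM, with a range of 0.4 nM to 6.5 nM.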

Compound 4, inhibition constant in the Oxytocin receptor assay: 0.251 nM
Compound 4: middle estimate off by 6.4-fold (0.80 log units), on the high side, outside the stated range (below it).
By their numbers in the Oxytocin receptor assay, from the lowest: compound 3; then compounds 4 and 2 (each within the scatter of the next); then compound 1.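

For the compounds shown here, in the Oxytocin receptor assay the aromatic carbon next to the ring nitrogen proves responsive, with dimethylamino in place of methyl giving a 6.3-fold lower number from compound 1 to compound 4 (0.80 log units; beyond the scatter); the earlier steps touched only the amide and the saturated ring substituent, so this is the first reading at the pyridine substituent. In a physicochemical assay for solubility, read by HPLC (on this read-out higher numbers stand for higher solubility and lower numbers for lower solubility), compound 4 gives 233 ug/mL. In the physicochemical assay compound 1 gives > 236 ug/mL as a limit of the assay, so no step between the two can be read: the limit of > 236 ug/mL in the physicochemical assay, at which 1 of the 2 values shown sits.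

As far as these compounds go, whether methylamino, methoxy or a pyrrolidin-1-yl group on the same carbon would hold the lower number in the Oxytocin receptor assay stays open, so the step cannot yet be tied to any one feature of dimethylamino. Also open, from the compounds shown here alone, is whether dimethylamino adds to the pentan-3-yl change of compound 3 or to the pyrrolidin-1-yl amide of compound 2.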